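The compounds below may be only part of what the source reports. "The series", "measured", "known", "first", "only" and "open" are said of these compounds alone.

Measured in a functional assay on NB-4 cells (Homo sapiens) for cytotoxicity, read by CCK-8 assay, with a stated time of 24 h; a lower number here means a stronger inhibitor, a higher number a weaker inhibitor:
- compound 1 `C=CC(=O)N1C(=O)CC(c2ccc(C(F)(F)F)cc2)Sc2ccccc21`: 38600 nM
- compound 2 `C=CC(=O)N1C(=O)CC(c2ccccc2Cl)Sc2ccccc21`: 33800 nM
- compound 3 `C=CC(=O)N1C(=O)CC(c2ccccc2C(F)(F)F)Sc2ccccc21`: 35200 nM

These three compounds form a tight group. Compound 1, at 38600 nM, cannot be separated from either of the others, since all three values lie within the scatter of one another.

The next compound to be examined is compound 4 `C=CC(=O)N1C(=O)CC(c2ccc([N+](=O)[O-])cc2)Sc2ccccc21`, which keeps the core of compound 1 and changes one group. It carries nitro in place of trifluoromethyl on an aromatic carbon.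

Going by the values given here, only one measured step bears on this change, and only indirectly. It is a 1.0-fold higher number from compound 2 to compound 3 (0.02 log units; within the scatter), a swap of trifluoromethyl in place of chloro on an aromatic carbon, and it stays within the scatter. Among the compounds with values here, no measured compound carries nitro, so the data give no direct reading of that group. Within the data shown here, the one swap available moved the number by no more than the scatter, and the three values sit close together, so no step beyond the scatter is expected in this assay, and no direction is favoured.

The estimated step is a 1.2-fold lower number from compound 1 to compound 4 (0.08 log units; within the scatter), which would remain within the scatter. For compound 4 the expected value is 32000 nM, with an estimated range from 15000 nM to 60000 nM.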

Compound 4, half-maximal inhibitory concentration: 37700 nM
Compound 4: middle estimate off by 1.2-fold (0.07 log units), on the low side; measured number inside the range.
By their numbers in this assay, from the lowest: compounds 2, 3, 4 and 1 (each within the scatter of the next).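

In this assay, placing nitro where compound 1 carries trifluoromethyl, on an aromatic carbon para to a large group, gives a 1.0-fold lower number from compound 1 to compound 4 (0.01 log units; within the scatter), so the two groups cannot be told apart at this position. Going by these compounds alone, the earlier compounds offered only an indirect reading, a 1.0-fold higher number from compound 2 to compound 3 (0.02 log units; within the scatter), which concerned chloro and trifluoromethyl; this step is the first direct reading for nitro and shows that exchanging the three fluorine atoms and their carbon for a group with hydrogen-bond acceptors leaves the number within the scatter. No measurement shown here accounts for this result.

Whether any group at this position can produce a step beyond the scatter remains open, since an amine, a carboxylic acid or a longer chain does not appear among the compounds shown. Also open, on these data alone, is whether changes elsewhere on the core of compound 1 would move the number in this assay more than the exchange of nitro for trifluoromethyl does.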